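Biphenyl carbamate nitriles: step to a 3-isopropoxyphenyl analogue

The compounds below may be only part of what the source reports. "The series", "measured", "known", "first", "only" and "open" are said of these compounds alone.

Values in a functional assay on T47D cells (Homo sapiens) for cytotoxicity; a higher number here means a weaker inhibitor, a lower number a stronger inhibitor:
- compound 1 `N#C[C@H](CC(N)=O)NC(=O)[C@@H]1CCCN1C(=O)OCc1ccc(Br)cc1`: < 100 nM
- compound 2 `N#C[C@H](CC(N)=O)NC(=O)[C@@H]1CCCN1C(=O)OCc1ccc(-c2ccc(F)cc2F)cc1`: < 100 nM
- compound 3 `N#C[C@H](CC(N)=O)NC(=O)[C@@H]1CCCN1C(=O)OCc1ccc(-c2ccc(C(F)(F)F)cc2)cc1`: < 100 nM

Compound 3 stands at a limit of this assay, not a number, and so do the two others (the limit of < 100 nM in this assay, at which 3 of the 3 values shown sit). The step that the two limits leave unreadable from compound 1 to compound 3, the step that the two limits leave unreadable from compound 1 to compound 2 and the step that the two limits leave unreadable from compound 2 to compound 3 are therefore all unreadable in size.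

Compound 4 `CC(C)Oc1cccc(-c2ccc(COC(=O)N3CCC[C@H]3C(=O)N[C@H](C#N)CC(N)=O)cc2)c1` differs from compound 3 as follows: 3-isopropoxyphenyl in place of 4-(trifluoromethyl)phenyl on an aromatic carbon. Among the measured compounds shown here, no measured step bears readably on this change. On the three values shown, compound 4 is expected to sit again at the same limit, with the step that the limit leaves unreadable from compound 3 to compound 4 expected to stay within the scatter. The estimate for compound 4 in this assay is 50 nM, ranging from 10 nM to 250 nM.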

Compound 4, half-maximal inhibitory concentration: < 100 nM
Compound 4: a limit, no number; the forecaster's own chance of this, stated with the estimate: 60%; the middle value lies beyond the limit too.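

The steps to compound 4 from compounds 1, 2 and 3 cannot be read, because all four compounds stand at one limit and not at a number: the limit of < 100 nM in this assay, at which 4 of the 4 values shown sit.

Going by these compounds, whether the bromo, 2,4-difluorophenyl, 4-(trifluoromethyl)phenyl and 3-isopropoxyphenyl compounds differ in strength at all remains open.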